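A few compounds are considered here, and "the series" means these few. Any claim that something is new, unique, unknown or untested is made for them only; others in the source may bear on it.

Values in a functional assay on thoracic aorta (Rattus norvegicus, strain Wistar), with a stated time of 15 min; a lower number here means that less compound is needed, a higher number that more compound is needed for the effect:
- Compound 1 `CCOc1ccc(Br)cc1C(C)NC(=O)NS(=O)(=O)c1ccc(Cl)cc1`: 171000 nM
- Compound 2 `CCOc1ccc(Br)cc1C(C)NC(=O)NS(=O)(=O)c1ccc(C)cc1`: > 300000 nM, a limit of the assay
- Compound 3 `CC(C)Oc1ccc(Br)cc1C(C)NC(=O)NS(=O)(=O)c1ccc(Cl)cc1`: not yet measured

Within the data shown here, compound 1 holds the only actual number in this assay, since the other result is the limit recorded for compound 2. Compound 3 differs from compound 1 by methyl in place of hydrogen on a saturated chain carbon bound to an oxygen on an aromatic ring and a saturated chain carbon, which turns ethoxy to isopropoxy. Among the measured compounds shown here, the sole measured step, an at least 1.7-fold higher number from compound 1 to compound 2 (0.24 log units; that floor lies within the scatter), is a methyl in place of chloro on an aromatic carbon, a different change at a different place, so it bears only loosely. No step beyond the scatter is therefore expected in this assay, and the expected step is a 1.3-fold lower number from compound 1 to compound 3 (0.12 log units; within the scatter). For compound 3 the estimated value is 130000 nM, with an expected range of 45000 nM to 300000 nM.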

Compound 3, half-maximal effective concentration: 122000 nM
For compound 3 the middle estimate is 1.1-fold (0.03 log units) above the measured one; low and high end bracket the measured number.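

Turning ethoxy to isopropoxy gives a 1.4-fold lower number from compound 1 to compound 3 (0.15 log units; within the scatter) in this assay. Among these compounds, this is the first reading at this place on the shared core, and it shows that a methyl in place of hydrogen on this saturated chain carbon leaves the number within the scatter. The only other comparison with compound 1 ends at a limit, and compound 2 gives no actual number: the limit of > 300000 nM in this assay, at which 1 of the 3 values shown sits.

On these data alone, whether a longer chain or an amine at this place would move the number beyond the scatter stays open. So does whether the isopropoxy result holds with methyl in place of chloro on the aromatic carbon.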